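Phenyl for Methyl on a Fused Bicyclic Core

The source may report more compounds than this note shows. Statements on the series, on what has been measured and on what is new or still open speak of the compounds shown alone.

Compound 1 `Cc1cc(CO)c2n1[C@@H](c1ccccc1)SC2` gives 63900 nM in a functional assay on MCF7 cells (Homo sapiens) for cytotoxicity, read by MTT assay, with a stated time of 48 h; on this read-out lower numbers stand for stronger inhibition and higher numbers for weaker inhibition.
Compound 2 `Cc1c(CO)c(CO)c2n1[C@@H](c1ccccc1)SC2` gives 1900 nM in this assay.

Compound 2 holds the lowest number of the two measured compounds, and the step of a 34-fold lower number from compound 1 to compound 2 (1.53 log units; beyond the scatter) separates it from compound 1 by a hydroxymethyl in place of hydrogen on an aromatic carbon. Compound 3 `OCc1c(CO)c(-c2ccccc2)n2c1CS[C@@H]2c1ccccc1` differs from compound 2 by phenyl in place of methyl on an aromatic carbon. For the measured compounds named here, no measured step touches this exchange: the only known step concerns a hydroxymethyl and says nothing about replacing methyl with phenyl. Without any support for a shift in either direction, compound 3 is expected to show a step of a 1.3-fold lower number from compound 2 to compound 3 (0.10 log units; within the scatter) in this assay, which stays within the scatter. Compound 3 is therefore estimated at 1500 nM, with a range from 300 nM to 8000 nM that allows for the uncertainty of an untested change.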

Compound 3, half-maximal inhibitory concentration: 61800 nM
For compound 3 the middle estimate is 41-fold (1.61 log units) below the measured one; measured number above the stated range.
By their numbers in this assay, from the lowest: compound 2; then compounds 3 and 1 (each within the scatter of the next).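

In this assay the aromatic carbon next to the ring nitrogen turns out to be sensitive to what it carries: phenyl in place of methyl gives a 33-fold higher number from compound 2 to compound 3 (1.51 log units; beyond the scatter) and so goes against the low number of compound 2. For the compounds shown here, the only earlier step, a 34-fold lower number from compound 1 to compound 2 (1.53 log units; beyond the scatter), concerned a hydroxymethyl on a different aromatic carbon, so it is this exchange that first shows a large change in the opposite direction on the shared core. Nothing available gives a reason for this rise.

The compounds shown leave open whether the rise belongs to phenyl itself or would also appear with an ethyl chain or a cyclopropyl ring on this carbon. They also leave open whether an amine or a carboxylic acid on the entering phenyl would change the size of the step.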